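From Chloro to Bromo: One Halogen Step

The source may hold more compounds than are shown below. What is called first, only, known or untested is meant among the compounds shown, and "the series" means these compounds.

The measured compounds:
Compound 1 `COc1ccc(OC[C@@H]2CCN2)cn1` gives 1.3 nM in an assay on brain for binding affinity to Neuronal acetylcholine receptor; alpha4/beta2 (Rattus norvegicus), read by radioligand binding; a lower number here means a stronger inhibitor, a higher number a weaker inhibitor.
Compound 2 `Fc1cncc(OC[C@@H]2CCN2)c1` gives 0.076 nM in this assay.
Compound 3 `Clc1cncc(OC[C@@H]2CCN2)c1` gives 0.042 nM in this assay.

Compound 3 has the lowest number of the three; compound 2 stands closest to it, within the scatter, while compound 1 lies furthest away, beyond the scatter. Compound 4 `Brc1cncc(OC[C@@H]2CCN2)c1` differs from compound 3 in one place: bromo in place of chloro on an aromatic carbon. For the measured compounds named here, the single measured step that bears on this change is a 1.8-fold lower number from compound 2 to compound 3 (0.26 log units; within the scatter), which stayed within the scatter. Exchanging one halogen for another has so far produced no clear shift, so no step beyond the scatter is expected in this assay here either. Compound 4 is estimated at 0.035 nM, with a range from 0.012 nM to 0.1 nM. The expected step from compound 3 is a 1.2-fold lower number from compound 3 to compound 4 (0.08 log units; within the scatter).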

Compound 4, inhibition constant: 0.18 nM
The estimate for compound 4 lay 5.1-fold (0.71 log units) below the measured number; the measured number lies above the stated range.
By their numbers in this assay, from the lowest: compounds 3 and 2 (each within the scatter of the next); then compound 4; then compound 1.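

At this position the halogens are not interchangeable: in this assay bromo in place of chloro gives a 4.3-fold higher number from compound 3 to compound 4 (0.63 log units; beyond the scatter) and so lies beyond the scatter. Bromo in place of fluoro points the same way, with a 2.4-fold higher number from compound 2 to compound 4 (0.37 log units; beyond the scatter) as a second modest step beyond the scatter. The fluoro-to-chloro exchange stayed within the scatter, so its result does not carry over to bromo. No measurement shown accounts for this shift. Going by these compounds, how iodo, a nitrile or a methyl group would behave at this position remains open.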